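From a Substituted Phenyl Amide to a Thiazolyl Amide

The source may report more compounds than this note shows. Statements on the series, on what has been measured and on what is new or still open speak of the compounds shown alone.

Within the data shown here, compound 2 `COc1ccc(C(=O)Nc2c(C)cccc2Cl)cc1OC1CCCC1` gives 100 nM in an assay on isolated protein for inhibition of phosphodiesterase 4A (Sus scrofa) (a higher number here means a weaker inhibitor, a lower number a stronger inhibitor), the lower of the two numbers measured so far. Among the measured compounds shown here, compound 1 `COc1ccc(C(=O)Nc2c(F)cccc2Cl)cc1OC1CCCC1` gives 240 nM in this assay, and the only measured step is a 2.4-fold lower number from compound 1 to compound 2 (0.38 log units; beyond the scatter). Compound 3 `COc1ccc(C(=O)Nc2nccs2)cc1OC1CCCC1` has not yet been measured. It differs from compound 2 in one place: 1,3-thiazol-2-yl in place of 2-chloro-6-methylphenyl on an amide-type nitrogen. For the measured compounds named here, no measured step covers such an exchange; the step of a 2.4-fold lower number from compound 1 to compound 2 (0.38 log units; beyond the scatter) alters one group on the very ring that is now removed altogether, so it offers no direct guide to the new amide. The whole 2-chloro-6-methylphenyl gives way to 1,3-thiazol-2-yl. A sizeable change in the number is expected, more likely toward a higher one. The estimated value for compound 3 is 800 nM, with a range of 150 nM to 4000 nM, which means an expected step of an 8.0-fold higher number from compound 2 to compound 3 (0.90 log units; beyond the scatter).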

Compound 3, half-maximal inhibitory concentration: 6500 nM
Estimate against measurement, compound 3: 8.1-fold (0.91 log units) below; measured number above the stated range.
By their numbers in this assay, from the lowest: compound 2; then compound 1; then compound 3.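

In this assay the amide-type nitrogen proves far more sensitive to an exchange of its whole aryl group than the earlier change on the ring had shown: 1,3-thiazol-2-yl in place of 2-chloro-6-methylphenyl gives a 65-fold higher number from compound 2 to compound 3 (1.81 log units; beyond the scatter), whereas methyl in place of fluoro gave only a 2.4-fold lower number from compound 1 to compound 2 (0.38 log units; beyond the scatter). The exchange made on the fluoro analogue, 1,3-thiazol-2-yl in place of 2-chloro-6-fluorophenyl, also gives a large rise, a 27-fold higher number from compound 1 to compound 3 (1.43 log units; beyond the scatter), so the loss appears from both substituted phenyl amides. Nothing available accounts for the size of this loss.

The compounds shown do not separate the part played by the chloro group from that of the carbon-only ring itself, which an unsubstituted phenyl or a pyridin-2-yl on the same nitrogen could address. From the compounds shown here alone, whether a methyl or chloro group on the thiazole ring would lower the number also remains open.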